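The source may report more compounds than this note shows. Statements on the series, on what has been measured and on what is new or still open speak of the compounds shown alone.

Going by the values given here, compound 3 `COc1ccc(CN2C(=O)C(=O)c3cc(-c4ccc(C#N)cc4)ccc32)cc1` sits lowest of the two numbers so far in a functional assay on HepG2 cells (Homo sapiens) for antiproliferative activity, read by MTT assay, with a stated time of 48 h; a higher number here means a weaker inhibitor, a lower number a stronger inhibitor: compound 3 gives 890 nM. Its nearest neighbour is compound 1 `COc1ccc(CN2C(=O)C(=O)c3cc(-c4ccc(C(C)(C)C)cc4)ccc32)cc1`, which in this assay gives 4580 nM, and the step is a 5.1-fold lower number from compound 1 to compound 3 (0.71 log units; beyond the scatter). Compound 2 `COc1ccc(CN2C(=O)C(=O)c3cc(-c4ccc(C)cc4)ccc32)cc1` is reported in this assay only as a limit, > 10000 nM (the limit of > 10000 nM in this assay, at which 1 of the 3 values shown sits). The step of an at least 2.1-fold higher number from compound 1 to compound 2 (0.33 log units; beyond the scatter) is at least modest, and the step of an at least 11-fold lower number from compound 2 to compound 3 (1.05 log units; beyond the scatter) is large. Compound 4 `COc1ccc(CN2C(=O)C(=O)c3cc(-c4ccc5ccccc5c4)ccc32)cc1` differs from compound 3 in one place: naphthalen-2-yl in place of 4-cyanophenyl on an aromatic carbon. Every measured step here alters the same distal group, and the cyano compound gives the lowest number while the two hydrocarbon groups, methyl and tert-butyl, give higher ones; naphthalen-2-yl, like them, brings only carbon and no hydrogen-bond acceptor. Among the compounds with values here, a rise beyond the scatter is therefore expected, though its size is uncertain with only three compounds in hand. Compound 4 is estimated at 4000 nM, within a range of 1200 nM to 12000 nM, a step of a 4.5-fold higher number from compound 3 to compound 4 (0.65 log units; beyond the scatter) that is expected to be modest.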

Compound 4, half-maximal inhibitory concentration: > 10000 nM
Compound 4 gave a limit, no number; the forecaster's own chance of this, stated with the estimate: 25%; middle value at least 2.5-fold (0.39 log units) from the limit.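

In this assay, replacing 4-cyanophenyl with naphthalen-2-yl shows that a larger aromatic group of carbon only does not keep the number of compound 3 at this position, with an at least 11-fold higher number from compound 3 to compound 4 (1.05 log units; beyond the scatter). The same change made from the 4-(tert-butyl)phenyl group gives an at least 2.1-fold higher number from compound 1 to compound 4 (0.33 log units; beyond the scatter), so all three groups of carbon only now give higher numbers than the nitrile, though compound 1 alone among them still gives a measured number. The step from compound 2 to compound 4 cannot be read, as both values are limits, and compound 4 now shares that limit with compound 2: the limit of > 10000 nM in this assay, at which 2 of the 4 values shown sit.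

The compounds shown leave open whether the nitrile itself sets the lower number. A methoxy group, an amine or a carboxylic acid at the same place on the phenyl ring could test this.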